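The source may hold more compounds than are shown below. What is called first, only, known or untested is meant among the compounds shown, and "the series" means these compounds.

Compound 3 `N#C/C(=C\c1ccccc1OS(=O)(=O)c1ccc(F)cc1)C(=O)Nc1nnc(Cc2cccc3ccccc23)s1` gives the lowest of the three numbers in an ADME assay on HEK-293T cells (Homo sapiens) for inhibition, read by CCK-8 assay, with a stated time of 48 h, tested at 20 uM; a higher number here means more inhibition of growth at the concentration tested, a lower number less inhibition of growth: compound 3 gives 15%. Compound 1 `COc1ccc(S(=O)(=O)Oc2ccccc2/C=C(\C#N)C(=O)Nc2nnc(Cc3cccc4ccccc34)s2)cc1` gives 29% and compound 2 `N#C/C(=C\c1ccccc1OS(=O)(=O)c1ccc([N+](=O)[O-])cc1)C(=O)Nc1nnc(Cc2cccc3ccccc23)s1` gives 25%. The difference a number 14 percentage points lower from compound 1 to compound 3 (beyond the scatter) is beyond the scatter, whereas a number 10 percentage points lower from compound 2 to compound 3 (within the scatter) and a number 4 percentage points lower from compound 1 to compound 2 (within the scatter) are within it. Compound 4 `Cc1ccc(Cc2nnc(NC(=O)/C(C#N)=C/c3ccccc3OS(=O)(=O)c3ccc(F)cc3)s2)cc1` differs from compound 3 by 4-methylphenyl in place of naphthalen-1-yl on a saturated chain carbon bound to an aromatic carbon. Among the measured compounds shown here, all three measured steps lie elsewhere on the shared core, where methoxy, nitro and fluoro exchange on an aromatic carbon, so none of them touches the part that changes here; the data hold no step that bears directly on this change. For the measured compounds named here, what they do show is a set that sits in a narrow band, with only one step beyond the scatter. A step of no change at the digits printed from compound 3 to compound 4 (within the scatter) is expected, one that is expected to stay within the scatter. Compound 4 is estimated at 15%, between 0% and 35%.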

Compound 4, percent growth inhibition at one concentration: 11%
Compound 4: middle estimate off by 4 percentage points, on the high side; measured number inside the range.
By their numbers in this assay, from the lowest: compounds 4, 3, 2 and 1 (each within the scatter of the next, the first and the last beyond it).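

In this assay, among the compounds shown here, the step of a number 4 percentage points lower from compound 3 to compound 4 (within the scatter) is the first reading at this position, where the earlier steps all changed the group on the other aromatic ring. Replacing naphthalen-1-yl with 4-methylphenyl takes away one of the two six-membered aromatic rings, yet this pair shows no change beyond the scatter, so growth inhibition at the concentration tested does not separate these two groups. No measurement shown offers a reason for this result.

On these data alone, what an amine, a carboxylic acid or a longer chain would do in place of these carbon-only aromatic groups remains open. So does whether 4-methylphenyl would behave the same way alongside methoxy or nitro, since this pair carries only fluoro.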